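The source may hold more compounds than are shown below. What is called first, only, known or untested is meant among the compounds shown, and "the series" means these compounds.

Three compounds from this series were tested for their ability to raise cyclic adenosine monophosphate in a functional assay on CHO-K1 cells for agonist activity at G-protein coupled receptor 6 (Homo sapiens), read by TR-FRET and cAMP accumulation, with a stated time of 20 h; a lower number here means that less compound is needed, a higher number that more compound is needed for the effect. Compound 1 `CC(C)Nc1nc2cc(C#N)ncc2nc1N1CCC(Oc2ccc(F)cc2F)CC1` gives 55000 nM in this assay. Compound 2 `Cc1cc2nc(N3CCC(Oc4ccc(F)cc4F)CC3)c(NC3CC3)nc2cn1` gives 95000 nM. Compound 3 `CC(C)Nc1nc2c(nc1N1CCC(Oc3ccc(F)cc3F)CC1)C=CNC2` gives 100000 nM, the highest of the three numbers, though its gaps to compound 2 and to compound 1 both lie within the scatter of this assay, so no ordering among the three can be drawn.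

Compound 4 `CC(=O)N1C=Cc2nc(N3CCC(Oc4ccc(F)cc4F)CC3)c(NC(C)C)nc2C1` differs from compound 3 by acetyl in place of hydrogen on an amine nitrogen in a ring. For the measured compounds named here, no pair of measured compounds shows the effect of such a change, so any expectation rests on the weak activity shared by compounds 1 to 3. The step from compound 3 to compound 4 is expected to be a 1.1-fold lower number from compound 3 to compound 4 (0.05 log units; within the scatter), no shift beyond the scatter. Compound 4 is therefore estimated at 90000 nM in this assay, within a range from 30000 nM to 300000 nM.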

Compound 4, half-maximal effective concentration: 34000 nM
Compound 4: the middle estimate sits 2.6-fold (0.42 log units) above what was measured; the measured number falls inside the stated range.
By their numbers in this assay, from the lowest: compounds 4, 1, 2 and 3 (each within the scatter of the next, the first and the last beyond it).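

In this assay, for the compounds shown here, acetyl in place of hydrogen on the amine nitrogen in the ring gives a 2.9-fold lower number from compound 3 to compound 4 (0.47 log units; beyond the scatter), the first step that can be read. This ring nitrogen therefore accepts an acetyl group with a modest fall in the number, although compound 4 still needs 34000 nM. Nothing shown here explains the shift.

As far as these compounds go, whether the carbonyl matters or any group on this nitrogen would do the same stays open. A methyl group or a longer acyl chain at this position would separate the two.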